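Replacing the pentylphenyl arm of compound 2 with hydroxyethyl

A few compounds are considered here, and "the series" means these few. Any claim that something is new, unique, unknown or untested is made for them only; others in the source may bear on it.

Notes on the series. The measured set holds three compounds: compound 1 `CCCCCc1ccc(-c2cn(C/C=C3\OC(=O)C(OCc4ccccc4)=C3OCc3ccccc3)nn2)cc1`, compound 2 `CCCCCc1ccc(-c2cn(C[C@H](O)[C@H]3OC(=O)C(OCc4ccccc4)=C3OCc3ccccc3)nn2)cc1` and compound 3 `COc1ccc(-c2cn(C/C=C3\OC(=O)C(OCc4ccccc4)=C3OCc3ccccc3)nn2)cc1`. In a functional assay on HCT-116 cells (Homo sapiens) for antiproliferative activity, read by MTT assay, with a stated time of 72 h (a higher number here means a weaker inhibitor, a lower number a stronger inhibitor), compound 2 gives 13800 nM. Compound 1 reaches only the limit of > 100000 nM in this assay. Compound 3 likewise reaches only the limit of > 100000 nM in this assay. Compound 2 thus stands as the only numerical result, the other two values being limits. Among the measured compounds shown here, the only step between measured compounds, a step that the two limits leave unreadable from compound 1 to compound 3, cannot be sized, both of its ends resting at the limit of > 100000 nM in this assay, at which 2 of the 3 values shown sit.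

Compound 4 `O=C1O[C@H]([C@@H](O)Cn2cc(CCO)nn2)C(OCc2ccccc2)=C1OCc1ccccc1` is not yet measured. It differs from compound 2 by 2-hydroxyethyl in place of 4-pentylphenyl on an aromatic carbon. No measured step touches this change: the unreadable step concerns a different alteration of the aryl group, and nothing shown removes that group from the five-membered ring. The expectation rests on compound 2 alone, the only number shown at 13800 nM, and on what leaves against what enters. Compound 4 is expected at 60000 nM, within 15000 nM to 150000 nM. The expected step is a 4.3-fold higher number from compound 2 to compound 4 (0.64 log units; beyond the scatter), a loss. A reading that is only a limit would not surprise.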

Compound 4, half-maximal inhibitory concentration: 72700 nM
For compound 4 the middle estimate is 1.2-fold (0.08 log units) below the measured one; the range from low to high includes it.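

In this assay, among the compounds shown here, the change at this aromatic carbon of the five-membered ring, 2-hydroxyethyl in place of 4-pentylphenyl, gives a 5.3-fold higher number from compound 2 to compound 4 (0.72 log units; beyond the scatter), the first step whose size can be read. The 4-pentylphenyl group is therefore not required for a numerical reading: its 11 heavy atoms and six-membered aromatic ring leave, 3 heavy atoms with a hydrogen-bond donor and acceptor enter, and the loss remains modest. The only other outcome shown in this assay is a limit, which gives no number: the limit of > 100000 nM in this assay, at which 2 of the 4 values shown sit.

This single step changes ring, chain length and hydroxyl together, so it cannot say which of them accounts for the loss; a plain phenyl, an unbranched pentyl chain or a 2-aminoethyl group on the same carbon would separate these parts. The step between compound 1 and compound 3 cannot be read, as both ends are limits, so the effect of the group on the phenyl ring also remains open, and a carboxylic acid or a longer hydroxyalkyl chain on the aromatic carbon is untested in the compounds shown here.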